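The source may hold more compounds than are shown below. What is called first, only, known or untested is meant among the compounds shown, and "the series" means these compounds.

Among the measured compounds shown here, compound 1 `COc1ccc(NC(=O)c2nnc(COc3ccc(CCC(=O)O)cc3)s2)cc1` is one of two compounds measured in a functional assay on CHO cells for agonist activity at Free fatty acid receptor 1 (Homo sapiens), read by calcium flux; a lower number here means that less compound is needed, a higher number that more compound is needed for the effect. In this assay compound 1 gives > 10000 nM, which is a limit of the assay rather than a measured number, so compound 1 stands at the limit of > 10000 nM in this assay, at which 1 of the 2 values shown sits. Compound 2 `O=C(O)CCc1ccc(OCc2nnc(C(=O)Nc3ccccc3F)s2)cc1` gives 580 nM in this assay. For the measured compounds named here, the one measured step, an at least 17-fold lower number from compound 1 to compound 2 (1.23 log units; beyond the scatter), is therefore large and runs toward a lower number. Compound 3 `O=C(O)CCc1ccc(OCc2nnc(C(=O)Nc3ccc(F)c(F)c3)s2)cc1` carries the change (3,4-difluorophenyl in place of 4-methoxyphenyl on an amide-type nitrogen). This change resembles the measured step in that a fluorine-bearing phenyl replaces the 4-methoxyphenyl, though 2-fluorophenyl and 3,4-difluorophenyl are not the same group, so a step in the same direction is expected, with its size uncertain. The step expected here is an at least 11-fold lower number from compound 1 to compound 3 (1.04 log units; beyond the scatter). Compound 3 is thus estimated at 900 nM in this assay, with a range from 200 nM to 5000 nM.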

Compound 3, half-maximal effective concentration: 580 nM
The estimate for compound 3 lay 1.6-fold (0.19 log units) above the measured number, within the range that was stated.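

In this assay, a second fluorine-bearing phenyl on the amide-type nitrogen gives an at least 17-fold lower number from compound 1 to compound 3 (1.23 log units; beyond the scatter), so the large step away from 4-methoxyphenyl no longer rests on the 2-fluorophenyl group alone. Exchanging the two fluorinated groups gives no change at the digits printed from compound 2 to compound 3 (within the scatter), so 2-fluorophenyl and 3,4-difluorophenyl cannot be told apart at this position in this read-out, with one fluorine or two on the ring. Compound 1 remains a limit of the assay, so the full size of both steps from it stays unknown: the limit of > 10000 nM in this assay, at which 1 of the 3 values shown sits.

Going by these compounds, what an unsubstituted phenyl or a 4-chlorophenyl on the amide-type nitrogen would give remains open, and with it whether the step follows the fluorine or the loss of the methoxy group. Also open, on these data alone, is how a pyridine ring at this position, or a longer chain carrying the carboxylic acid, would read.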